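A few compounds are considered here, and "the series" means these few. Any claim that something is new, unique, unknown or untested is made for them only; others in the source may bear on it.

Of the compounds shown here, two that share one core have been measured so far. Compound 1 `COc1ccc(C(=O)/C=C/c2cc3ccccc3[nH]c2=O)cc1` gives 3660 nM in a functional assay on COLO 205 cells (Homo sapiens) for cytotoxicity, read by sulforhodamine B assay, with a stated time of 24 h; on this read-out lower numbers stand for stronger inhibition of growth and higher numbers for weaker inhibition of growth. Compound 2 `O=C(/C=C/c1cc2ccccc2[nH]c1=O)c1ccc(O)cc1` gives 4050 nM in this assay, which is the highest of the two numbers, though compound 1 stands within the scatter of it. Going by the values given here, the single measured step, a 1.1-fold higher number from compound 1 to compound 2 (0.04 log units; within the scatter), is thus within the scatter and shows no effect of exchanging methyl for hydrogen on that oxygen.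

Compound 3 `O=C(/C=C/c1cc2ccccc2[nH]c1=O)c1ccc(Cl)cc1` has not yet been measured. It differs from compound 2 by chloro in place of hydroxy on an aromatic carbon. Among the compounds with values here, no measured pair involves a chloro group, so the only step that bears on this change, a 1.1-fold higher number from compound 1 to compound 2 (0.04 log units; within the scatter), does so indirectly: it concerns the same aromatic carbon and lay within the scatter. Because a 1.1-fold higher number from compound 1 to compound 2 (0.04 log units; within the scatter) lay within the scatter, no step beyond the scatter is expected in this assay for compound 3, and the direction is left open. Compound 3 is therefore estimated at 3200 nM, with a range from 1200 nM to 8500 nM. This estimate corresponds to an expected step of a 1.3-fold lower number from compound 2 to compound 3 (0.10 log units; within the scatter).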

Compound 3, concentration for 50% growth inhibition: 10100 nM
Estimate against measurement, compound 3: 3.2-fold (0.50 log units) below; measured number above the stated range.
By their numbers in this assay, from the lowest: compounds 1 and 2 (each within the scatter of the next); then compound 3.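

Until now, the hydroxy and methoxy compounds could not be told apart at this aromatic carbon, para to a large group. Chloro is the first group there to shift the number beyond the scatter in this assay, with a 2.5-fold higher number from compound 2 to compound 3 (0.40 log units; beyond the scatter) and a 2.8-fold higher number from compound 1 to compound 3 (0.44 log units; beyond the scatter), both steps pointing to weaker inhibition of growth, so this position is not indifferent to what it carries. No measurement at hand accounts for the shift from 4-hydroxyphenyl to 4-chlorophenyl.

Going by these compounds alone, with chloro as the only group here not attached through oxygen, the compounds leave open whether the modest loss belongs to chloro itself or would accompany other replacements of the oxygen-linked groups. An amine, a carboxylic acid or a longer chain such as butoxy on the same aromatic carbon could show whether the number keeps rising, returns to the level of compound 1 and compound 2, or falls below it.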